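Styryl in place of biaryl on a bile acid receptor ligand

The source may hold more compounds than are shown below. What is called first, only, known or untested is meant among the compounds shown, and "the series" means these compounds.

Among the compounds with values here, compound 1 `COC(=O)/C=C/c1cccc(N(Cc2ccc(-c3ccc(F)c(F)c3)cc2)C(=O)C2CCCCC2)c1` is the only compound with a number in an assay on isolated protein with Bile acid receptor (Homo sapiens) as the target (a lower number here means that less compound is needed, a higher number that more compound is needed for the effect), where compound 1 gives 72 nM. Compound 2 `CC(C)(C)OC(=O)/C=C/c1ccc(CN(C(=O)C2CCCCC2)c2cccc(/C=C/C(=O)OC(C)(C)C)c2)cc1` does not reach a number, and stops at the limit of the assay with > 1000 nM. Compound 3 `COC(=O)/C=C/c1cccc(N(Cc2ccc(/C=C/c3cccc(Cl)c3)cc2)C(=O)C2CCCCC2)c1` differs from compound 1 in one place: 2-(3-chlorophenyl)ethenyl in place of 3,4-difluorophenyl on an aromatic carbon. Within the data shown here, no step between two measured compounds is known, so the size of this change can only be judged roughly; no shift beyond the usual scatter is expected. Compound 3 is therefore expected to give about 100 nM, between 30 nM and 400 nM. The expected step is a 1.4-fold higher number from compound 1 to compound 3 (0.14 log units; within the scatter).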

Compound 3, half-maximal effective concentration: 165 nM
Compound 3: middle estimate off by 1.7-fold (0.22 log units), on the low side; low and high end bracket the measured number.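

In this assay, 2-(3-chlorophenyl)ethenyl in place of 3,4-difluorophenyl gives a 2.3-fold higher number from compound 1 to compound 3 (0.36 log units; beyond the scatter), a modest step. The aromatic carbon para to a large group therefore responds to this exchange, though compound 3 still gives a measurable 165 nM. Nothing shown accounts for the step.

The ethenyl link and the swap of two fluorines for one chlorine arrive together, and their shares cannot be separated. As far as these compounds go, how a plain phenyl, an amine or a carboxylic acid would read at this position remains open.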